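The source may report more compounds than this note shows. Statements on the series, on what has been measured and on what is new or still open speak of the compounds shown alone.

Three compounds sharing the core of compound 1 `N#CCn1c(=N)sc2cc(OC(F)(F)F)ccc21` have been tested in a functional assay on the whole organism with Rattus norvegicus as the target (on this read-out lower numbers stand for an effect already at smaller amounts and higher numbers for an effect only at larger amounts of compound), differing only in the group on a saturated chain carbon bound to an aromatic nitrogen. Compound 1 gives 3.5 mg/kg. Compound 3 `CNS(=O)(=O)CCn1c(=N)sc2cc(OC(F)(F)F)ccc21`, carrying (methylsulfamoyl)methyl in that place, gives 4 mg/kg, which sits within the scatter of compound 1, as the step of a 1.1-fold higher number from compound 1 to compound 3 (0.06 log units; within the scatter) shows. For compound 2 `N=c1sc2cc(OC(F)(F)F)ccc2n1Cc1ccccc1` only a limit was recorded, > 10 mg/kg, described by the limit of > 10 mg/kg in this assay, at which 1 of the 3 values shown sits. The steps of an at least 2.8-fold higher number from compound 1 to compound 2 (0.45 log units; beyond the scatter) and an at least 2.5-fold lower number from compound 2 to compound 3 (0.39 log units; beyond the scatter) show that phenyl in this position moves the number beyond the scatter, while cyano and (methylsulfamoyl)methyl do not differ.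

Compound 4 `CS(=O)(=O)CCn1c(=N)sc2cc(OC(F)(F)F)ccc21` differs from compound 3 only in methyl in place of methylamino on a sulfonyl sulfur. For the measured compounds named here, no measured step touches the sulfonyl sulfur, so the comparison rests on the observation that compound 1 and compound 3 agree within the scatter across a larger change of the chain group. Compound 4 is therefore expected to show no step beyond the scatter, no change at the digits printed from compound 3 to compound 4 (within the scatter), with an estimated 4 mg/kg in this assay, between 2 mg/kg and 8 mg/kg.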

Compound 4, dose for half-maximal effect: 1.8 mg/kg
Compound 4: the middle estimate sits 2.2-fold (0.35 log units) above what was measured; the measured number lies below the stated range.
By their numbers in this assay, from the lowest: compounds 4, 1 and 3 (each within the scatter of the next, the first and the last beyond it). At a limit, above all of these: compound 2.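

The sulfonyl sulfur proves to be a place where a small change registers in this assay (a 2.2-fold lower number from compound 3 to compound 4 (0.35 log units; beyond the scatter)), whereas cyano and (methylsulfamoyl)methyl had not differed on the chain carbon. Compound 4 is thus set apart from compound 3 but not from compound 1 (a 1.9-fold lower number from compound 1 to compound 4 (0.29 log units; within the scatter)), so the change at the sulfur does not separate the sulfonyl compounds from the nitrile. The step from phenyl (an at least 5.5-fold lower number from compound 2 to compound 4 (0.74 log units; beyond the scatter)) rests on a limit for compound 2 and not on a number: the limit of > 10 mg/kg in this assay, at which 1 of the 4 values shown sits.

On these data alone, whether an ethyl or a dimethylamino group on the sulfonyl sulfur would read like methyl or like methylamino stays open. So does the effect of a longer chain in place of 2-(methylsulfonyl)ethyl.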